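The source may report more compounds than this note shows. Statements on the series, on what has been measured and on what is new or still open speak of the compounds shown alone.

Compound 1 `COc1ccc(C(=O)/C=C/c2ccc(F)c(F)c2)c(OC)c1`: 5300 nM
Compound 2 `O=C(/C=C/c1ccc(O)cc1)c1ccc(O)cc1`: 59000 nM

Of the compounds shown here, two have been measured in a functional assay (Homo sapiens) for inhibition; a higher number here means a weaker inhibitor, a lower number a stronger inhibitor. Compound 1 `COc1ccc(C(=O)/C=C/c2ccc(F)c(F)c2)c(OC)c1` gives 5300 nM in this assay. Compound 2 `O=C(/C=C/c1ccc(O)cc1)c1ccc(O)cc1` gives 59000 nM in this assay, the highest of the two numbers, so compound 2 is the weaker inhibitor of this pair, and its gap to compound 1 lies beyond the usual scatter of repeated measurements.

Compound 3 `CN(C)c1ccc(/C=C/C(=O)c2ccc(O)cc2)cc1` has not yet been measured. It differs from compound 2 in one place: dimethylamino in place of hydroxy on an aromatic carbon. The change sits on an aromatic carbon of a six-membered aromatic ring of carbon only, para to a large group. Going by the values given here, no measured pair shows this same change, so there is no step to lean on; the two numbers of compound 1 and compound 2 only show how far values in this assay can spread within this small set.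

A modest step toward a lower number is expected from compound 2 to compound 3, about a 3.0-fold lower number from compound 2 to compound 3 (0.47 log units; beyond the scatter), though a step within the scatter cannot be ruled out. Compound 3 is estimated at 20000 nM in this assay, with a range from 5000 nM to 80000 nM.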

Compound 3, half-maximal inhibitory concentration: 130000 nM
The estimate for compound 3 lay 6.5-fold (0.81 log units) below the measured number, outside the stated range (above it).
By their numbers in this assay, from the lowest: compound 1; then compound 2; then compound 3.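

In this assay, going by these compounds alone, the only single-place change available so far is dimethylamino in place of hydroxy on an aromatic carbon, para to a large group, and it gives a 2.2-fold higher number from compound 2 to compound 3 (0.34 log units; beyond the scatter). This shows that the position responds to the change, and that here the response is toward weaker inhibition: dimethylamino does not improve on hydroxy at this place. The swap brings 3 heavy atoms in place of 1 and 0 hydrogen-bond donors in place of 1, but no measurement here explains the step, so neither difference can be singled out as the one that matters.

The compounds shown leave open how a simple amino group, which would keep a nitrogen at this place while carrying hydrogens on it, or a carboxylic acid would behave here, and either result would help to separate the two differences. Compound 1 differs from compound 2 and compound 3 in more than one place, so its lower number cannot be tied to this position.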